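Uridine diphosphate analogues: carboxypropylsulfanyl extension at the four-position

A few compounds are considered here, and "the series" means these few. Any claim that something is new, unique, unknown or untested is made for them only; others in the source may bear on it.

Measured in an in vitro functional assay on 1321-N1 cells for agonist activity at P2Y purinoceptor 6 (Homo sapiens); a lower number here means that less compound is needed, a higher number that more compound is needed for the effect:
- compound 1, `O=c1cc(I)n([C@@H]2O[C@H](COP(=O)(O)OP(=O)(O)O)[C@@H](O)[C@H]2O)c(=O)[nH]1`, 15 nM
- compound 2, `Cn1c(=O)ccn([C@@H]2O[C@H](COP(=O)(O)OP(=O)(O)O)[C@@H](O)[C@H]2O)c1=O`, 3300 nM
- compound 3, `CSc1ccn([C@@H]2O[C@H](COP(=O)(O)OP(=O)(O)O)[C@@H](O)[C@H]2O)c(=O)n1`, 2300 nM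

Compound 3 gives the second highest of the three numbers in this assay. Its nearest neighbour is compound 2, whose number lies within the scatter of that of compound 3, so no order between the two can be read. Compound 1 is the furthest, its number lying well below that of compound 3, beyond the scatter.

Compound 4, `O=C(O)CCCSc1ccn([C@@H]2O[C@H](COP(=O)(O)OP(=O)(O)O)[C@@H](O)[C@H]2O)c(=O)n1`, has not been measured. It differs from compound 3 as follows:
2-carboxyethyl in place of hydrogen on a saturated chain carbon bound to a sulfur

Among the measured compounds shown here, no step between two measured compounds involves this change, so nothing shows its effect. Only the large gap between compound 1 and compound 3 suggests that this position of the core is sensitive. For this assay the expectation is a step of a 1.7-fold higher number from compound 3 to compound 4 (0.24 log units; within the scatter), with no clear direction beyond the scatter. Compound 4 is estimated at 4000 nM, range 800 nM to 20000 nM.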

Compound 4, half-maximal effective concentration: 8800 nM
Estimate against measurement, compound 4: 2.2-fold (0.34 log units) below; the range from low to high includes it.
By their numbers in this assay, from the lowest: compound 1; then compounds 3 and 2 (each within the scatter of the next); then compound 4.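

In this assay, among the compounds shown here, the change from methylsulfanyl to (3-carboxypropyl)sulfanyl gives a 3.8-fold higher number from compound 3 to compound 4 (0.58 log units; beyond the scatter) and is the only measured step at this place on the shared core. The long chain ending in a carboxylic acid therefore raises the number only modestly, and compound 4 still gives a measurable response. Nothing measured in the series accounts for the step.

Open, as far as these compounds go, is whether the step follows the carboxylic acid or the chain length. A plain butyl chain, a methyl ester or a shorter carboxymethyl group on the sulfur would separate the two.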